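The compounds below may be only part of what the source reports. "The series", "measured", "known", "first", "only" and "open" are said of these compounds alone.

Compound 1 `N#Cc1ccc(NC(=O)c2ccc(F)c([N+](=O)[O-])c2)cc1C(F)(F)F` and compound 2 `N#Cc1ccc(NC(=O)c2ccc(NCc3ccc(F)cc3)c([N+](=O)[O-])c2)cc1C(F)(F)F` share one core and differ at a single aromatic carbon, where a (4-fluorobenzyl)amino group in compound 2 replaces the fluoro of compound 1. In a functional assay on MDA-MB-231 cells (Homo sapiens) for antiproliferative activity, read by MTT assay, with a stated time of 72 h, tested at 2 mM (on this read-out lower numbers stand for less inhibition and higher numbers for more inhibition at the one concentration tested (going by the name of the read-out)), compound 1 gives 60%, while compound 2 gives 0%, the lowest of the two numbers; the step of a number 60 percentage points lower from compound 1 to compound 2 (beyond the scatter) is large. Compound 3 `N#Cc1ccc(NC(=O)c2ccc(NCc3ccc(F)cc3)c(N)c2)cc1C(F)(F)F` is not yet measured and differs from compound 2 by amino in place of nitro on an aromatic carbon. Within the data shown here, no measured step exchanges a nitro for an amino, so the single step recorded, from fluoro to (4-fluorobenzyl)amino, does not bear directly on it. With compound 2 already at the bottom of the read-out, the expected step of a number 5 percentage points higher from compound 2 to compound 3 (within the scatter) is small and upward at most. Compound 3 is estimated at 5%, in a range of 0% to 25%.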

Compound 3, a percentage reported as inhibition, at one concentration (the size of the read-out at that concentration, not a potency): 9.8%
Beside the measured number, compound 3's estimate is 4.8 percentage points below it; low and high end bracket the measured number.
By their numbers in this assay, from the lowest: compounds 2 and 3 (each within the scatter of the next); then compound 1.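

In this assay, amino in place of nitro on this aromatic carbon, ortho to a (4-fluorobenzyl)amino group, gives a number 9.8 percentage points higher from compound 2 to compound 3 (within the scatter). The earlier step concerned the carbon that carries the (4-fluorobenzyl)amino group; this step shows that, with that group in place, the read-out does not separate nitro from amino at the carbon ortho to it. Nothing on hand explains this outcome.

Open, from the compounds shown here alone, is whether a carboxylic acid or a methyl group on this carbon would read differently from nitro and amino, and whether the same exchange would read differently with fluoro in place of the (4-fluorobenzyl)amino group. Also open, going by these compounds, is how a simple amine or a longer chain would read in place of the (4-fluorobenzyl)amino group.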